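Pyridinyl swap on the shared core: stability outlook

This account rests on a few compounds, and the source may have more. Where it says the series, first, only, none or still open, it means among the compounds named here.

Among the compounds with values here, compound 1 `COc1ccnc(Nc2cc3[nH]c(-c4cccc(C(F)(F)F)c4)nc3cn2)c1` holds the higher of the two numbers so far in an ADME assay on microsomes from liver (Mus musculus) for metabolic stability, read by LC-MS, with a stated time of 30 min, tested at 0.1 uM (on this read-out higher numbers stand for a more stable compound and lower numbers for a less stable compound), giving 62%, though the gap to its only neighbour lies within the scatter. Compound 2 `Fc1ccc(Nc2cc3[nH]c(-c4cccc(C(F)(F)F)c4)nc3cn2)nc1` gives 54% in this assay ; the step of a number 8 percentage points lower from compound 1 to compound 2 (within the scatter), 5-fluoropyridin-2-yl in place of 4-methoxypyridin-2-yl on a nitrogen on an aromatic ring, stays within the scatter. Compound 3 `Fc1cnc(Nc2cc3[nH]c(-c4cccc(C(F)(F)F)c4)nc3cn2)c(F)c1` has not yet been measured. It differs from compound 1 thus: 3,5-difluoropyridin-2-yl in place of 4-methoxypyridin-2-yl on a nitrogen on an aromatic ring. Within the data shown here, the one measured step that bears on this change is the one from compound 1 to compound 2, and it stayed within the scatter. Among the measured compounds shown here, for the second fluorine of the 3,5-difluoropyridin-2-yl no measured step exists, so its contribution is unknown. The step to compound 3 is therefore expected to be small, a number 10 percentage points lower from compound 1 to compound 3 (within the scatter), not clearly beyond the scatter. Compound 3 is estimated at 52%, with a range from 35% to 70%.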

Compound 3, percent of the compound remaining: 49%
Beside the measured number, compound 3's estimate is 3 percentage points above it; the range from low to high includes it.
By their numbers in this assay, from the lowest: compounds 3, 2 and 1 (each within the scatter of the next, the first and the last beyond it).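

In this assay, within the data shown here, 3,5-difluoropyridin-2-yl in place of 4-methoxypyridin-2-yl on a nitrogen on an aromatic ring gives the first step at this position to pass the scatter, though only modestly: a number 13 percentage points lower from compound 1 to compound 3 (beyond the scatter). Among these compounds, the second fluorine on its own does not separate the two fluorinated compounds, with fluoro in place of hydrogen on an aromatic carbon giving a number 5 percentage points lower from compound 2 to compound 3 (within the scatter), so the series so far supports only the comparison with the 4-methoxypyridin-2-yl compound. No measurement at hand offers an explanation for either step.

Open, going by these compounds, is how an unsubstituted pyridin-2-yl, or one carrying a nitrile or an amine, would compare with these three groups on the shared core. Also open, on these data alone, is whether the same order would hold with a group other than trifluoromethyl on the shared core.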